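Solubility notes on a fused amine series

The source may report more compounds than this note shows. Statements on the series, on what has been measured and on what is new or still open speak of the compounds shown alone.

Measured so far:
compound 1 `c1ccc(Oc2ccc3c(NCCCNCc4ccco4)ccnc3c2)cc1`: 14500 nM
compound 2 `COc1ccc(F)cc1CNCCCNc1ccnc2cc(C3CCCCC3)ccc12`: 4200 nM

In a physicochemical assay for solubility, with a stated time of 18 h, at pH 7.4 (on this read-out lower numbers stand for lower solubility and higher numbers for higher solubility), compound 2 gives the lowest of the two numbers, with compound 1 standing higher by a gap beyond the usual scatter. Compound 3 `COc1cccc(Oc2ccc3c(NCCCNCc4cc(F)ccc4OC)ccnc3c2)c1` is not yet measured. It differs from compound 2 by 3-methoxyphenoxy in place of cyclohexyl on an aromatic carbon. Going by the values given here, no step between measured compounds exists to lean on, so the expectation rests on compound 1, which with its aryl ether group reaches 14500 nM. The step from compound 2 to compound 3 is expected to be upward, of moderate size, a 2.1-fold higher number from compound 2 to compound 3 (0.33 log units; beyond the scatter). Compound 3 is estimated at 9000 nM, between 4000 nM and 20000 nM.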

Compound 3, solubility: 14500 nM
Compound 3: the middle estimate sits 1.6-fold (0.21 log units) below what was measured, and the stated range covers the measured number.
By their numbers in this assay, from the lowest: compound 2; then compounds 1 and 3 (each within the scatter of the next).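

In this assay the exchange of cyclohexyl for 3-methoxyphenoxy gives a 3.5-fold higher number from compound 2 to compound 3 (0.54 log units; beyond the scatter) on an aromatic carbon of the shared core. Going by these compounds alone, this is the first step read at a single place, and it shows that the read-out responds to a change at this position. No measurement bears on the reason for the step. Still open, as far as these compounds go, is whether the step follows the ether oxygen, the aromatic ring or the methoxy group, and how a morpholine or a carboxylic acid at this carbon would read.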